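Sulfonamide Substituent Changes on a Shared Core

This account rests on a few compounds, and the source may have more. Where it says the series, first, only, none or still open, it means among the compounds named here.

Compound 1 `CNS(=O)(=O)c1ccc2c(c1)C(n1ccccc1=O)=CC(C)(C)O2` carries a methyl on its sulfonamide nitrogen, and in a functional assay on the whole organism (trachea) with Rattus norvegicus as the target (on this read-out higher numbers stand for larger maximal responses and lower numbers for smaller maximal responses), compound 1 gives 83%. Compound 2 `COc1ccc(NS(=O)(=O)c2ccc3c(c2)C(n2ccccc2=O)=CC(C)(C)O3)cc1` bears a 4-methoxyphenyl on that nitrogen instead, and in this assay compound 2 gives 84.2%. Among the measured compounds shown here, the single measured step, a number 1.2 percentage points higher from compound 1 to compound 2 (within the scatter), lies within the scatter, so compound 2 stands level with compound 1 on the two numbers available, neither value standing apart from the other. Compound 3 `CN(C)S(=O)(=O)c1ccc2c(c1)C(n1ccccc1=O)=CC(C)(C)O2` differs from compound 2 in one place: dimethylamino in place of (4-methoxyphenyl)amino on a sulfonyl sulfur. For the measured compounds named here, the one measured step bears directly on this change, since it too swapped one group against another at the sulfonamide nitrogen, and its size, a number 1.2 percentage points higher from compound 1 to compound 2 (within the scatter), stayed within the scatter. Going by the values given here, with only that step to go on, the estimated step of a number 1.2 percentage points lower from compound 2 to compound 3 (within the scatter) is expected to stay within the scatter as well, in no particular direction. Compound 3 is therefore estimated to give 83% in this assay, with a range from 70% to 95%.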

Compound 3, largest response reached (Emax), in percent of the reference or control that the assay uses: 74.1%
For compound 3 the middle estimate is 8.9 percentage points above the measured one; the measured number falls inside the stated range.
By their numbers in this assay, from the lowest: compounds 3, 1 and 2 (each within the scatter of the next, the first and the last beyond it).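

Swapping (4-methoxyphenyl)amino for dimethylamino on the sulfonyl sulfur gives a number 10.1 percentage points lower from compound 2 to compound 3 (beyond the scatter) in this assay and is the first step at this position to pass beyond the scatter, though only modestly, so the position is not wholly indifferent to the group it carries. Methyl in place of hydrogen on the sulfonamide nitrogen gives a number 8.9 percentage points lower from compound 1 to compound 3 (within the scatter) and stays within the scatter, so this smaller change alone cannot be read as moving the maximal response, and compound 3 stands apart only from compound 2. No measurement offered here accounts for the step beyond the scatter.

The change from compound 2 to compound 3 removes the six-membered aromatic ring and the hydrogen on the sulfonamide nitrogen together, and the compounds shown do not separate these two parts of the change. Going by these compounds, whether a plain phenyl, a benzyl or a morpholine on the sulfonyl sulfur would stand with compound 2 or with compound 3 remains open.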